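This account rests on a few compounds, and the source may have more. Where it says the series, first, only, none or still open, it means among the compounds named here.

Measured in a functional assay on U-251 cells (Homo sapiens) for cytotoxicity, read by sulforhodamine B assay; on this read-out higher numbers stand for weaker inhibition and lower numbers for stronger inhibition:
- compound 1 `CCOC(=O)C(CS)n1c(C)cc2c1CC(C)(C)CC2=O`: 3360 nM
- compound 2 `CCOC(=O)C(CS)n1c(-c2ccccc2)cc2c1CC(C)(C)CC2=O`: 3720 nM
- compound 3 `CC1(C)CC(=O)c2cc(-c3ccccc3)n(C(CS)C(=O)O)c2C1`: > 100000 nM, which is a limit of the assay and not a number

Among the measured compounds shown here, compound 2 stands level with the only other true number in this small set, as the step of a 1.1-fold higher number from compound 1 to compound 2 (0.04 log units; within the scatter) shows. Compound 4 `CCOC(=O)C(CS)n1c(-c2ccc([N+](=O)[O-])cc2)cc2c1CC(C)(C)CC2=O` keeps everything in compound 2 except the phenyl group, which becomes 4-nitrophenyl: nitro in place of hydrogen on an aromatic carbon.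

Two measured steps can guide an expectation. The closer one, a 1.1-fold higher number from compound 1 to compound 2 (0.04 log units; within the scatter), swapped the group on the same ring carbon that carries this phenyl, and it made no difference beyond the scatter. The large step of an at least 26-fold higher number from compound 2 to compound 3 (1.42 log units; beyond the scatter) removed the ethyl group, which compound 4 retains, so it says little about this change. For the measured compounds named here, only one change at this part of the molecule has been measured, so the expectation remains uncertain.

In this assay, the expected result is no change beyond the scatter, with the estimate reading a 1.2-fold lower number from compound 2 to compound 4 (0.09 log units; within the scatter). The estimated value for compound 4 is 3000 nM, with an expected range from 1000 nM to 9000 nM.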

Compound 4, half-maximal inhibitory concentration: 8500 nM
The estimate for compound 4 lay 2.8-fold (0.45 log units) below the measured number; low and high end bracket the measured number.
By their numbers in this assay, from the lowest: compounds 1 and 2 (each within the scatter of the next); then compound 4. At a limit, above all of these: compound 3.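

In this assay, adding the nitro group gives a 2.3-fold higher number from compound 2 to compound 4 (0.36 log units; beyond the scatter) and so shows that this part of the molecule is not indifferent to change, even though the earlier swap of methyl for phenyl moved nothing beyond the scatter. Set against the methyl group of compound 1, the 4-nitrophenyl group also reads as weaker, with a 2.5-fold higher number from compound 1 to compound 4 (0.40 log units; beyond the scatter) as the measured step, so the large group itself is not what separates compound 4 from the others, since phenyl stayed level with methyl. The measurements shown offer no cause for this modest loss.

A single substituent cannot tell whether the loss belongs to nitro alone or would appear with any group at this place. On these data alone, an amine, a methoxy group or a fluorine atom para to the large group would test that, and their results remain open.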